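The compounds below may be only part of what the source reports. "The series", "measured", "known", "first", "only" and "open" are said of these compounds alone.

Compound 1 `Cc1ccc(NC(=O)c2ccc(C(F)(F)F)cc2)cc1-n1cc(-c2cnc3cccnn23)cn1` belongs to a small set of amides built on a shared core and tested in a functional assay on U-937 cells (Homo sapiens) for antiproliferative activity, read by CCK-8 assay, with a stated time of 24 h; a lower number here means a stronger inhibitor, a higher number a weaker inhibitor. In this assay compound 1 gives > 20000 nM, which is a limit of the assay and not a number. Compound 2 `Cc1ccc(NC(=O)c2ccc(F)cc2)cc1-n1cc(-c2cnc3cccnn23)cn1` gives > 20000 nM, again a limit. Compound 3 `Cc1ccc(NC(=O)c2cccc(Cl)c2)cc1-n1cc(-c2cnc3cccnn23)cn1` gives > 20000 nM, also a limit. The steps a step that the two limits leave unreadable from compound 1 to compound 2, a step that the two limits leave unreadable from compound 1 to compound 3 and a step that the two limits leave unreadable from compound 2 to compound 3 therefore cannot be sized, as the limit of > 20000 nM in this assay, at which 3 of the 3 values shown sit, shows. Compound 4 `CCc1ccc(C(=O)Nc2ccc(C)c(-n3cc(-c4cnc5cccnn45)cn3)c2)cc1` differs from compound 1 by ethyl in place of trifluoromethyl on an aromatic carbon. Going by the values given here, no measured step gives a readable size for changing this aryl group, so no movement beyond the scatter can be foreseen. Compound 4 is expected to give 30000 nM, between 8000 nM and 100000 nM. The expected step is a step that the limit leaves unreadable from compound 1 to compound 4, most likely again only a limit.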

Compound 4, half-maximal inhibitory concentration: > 20000 nM
Compound 4 ended at the assay's limit (the forecaster's own chance of this, stated with the estimate: 85%); the middle value lies beyond the limit too.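

Compound 4, like compounds 1, 2 and 3, sits at a limit and not at a number, so none of its steps to them can be read: the limit of > 20000 nM in this assay, at which 4 of the 4 values shown sit.

The compounds shown leave open whether any change to this aryl group gives a readable value in this assay.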